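A few compounds are considered here, and "the series" means these few. Any claim that something is new, unique, unknown or untested is made for them only; others in the source may bear on it.

Compound 2 `COc1cc(F)ccc1-c1ccnc(Nc2ccc3c(N4CCCCC4)c(C(C)=O)c(=O)oc3c2)n1` gives the lowest number of the three measured in a functional assay on MV4-11 cells (Homo sapiens) for inhibition, read by luminescence and CellTiter-Glo, with a stated time of 72 h (on this read-out higher numbers stand for weaker inhibition and lower numbers for stronger inhibition), at 730 nM. Going by the values given here, compound 1 `COc1ccccc1-c1ccnc(Nc2ccc3c(C)c(C(C)=O)c(=O)oc3c2)n1` gives 10200 nM in this assay, and compound 3 `CC(=O)c1c(C)c2ccc(Nc3nccc(-c4cccnc4)n3)cc2oc1=O` gives 12900 nM; the only measured step between neighbours, a 1.3-fold higher number from compound 1 to compound 3 (0.10 log units; within the scatter), concerns a different part of the shared core and does not bear on the change considered here. Compound 4 `COc1cc(F)ccc1-c1ccnc(Nc2ccc3c(N4CCN(C)CC4)c(C(C)=O)c(=O)oc3c2)n1` differs from compound 2 by 4-methylpiperazin-1-yl in place of piperidin-1-yl on an aromatic carbon. Among the compounds with values here, no measured step touches this group, so nothing in the data supports expecting a step beyond the scatter in either direction in this assay. Compound 4 is therefore estimated at 1000 nM, with a range from 300 nM to 3500 nM, and the expected step is a 1.4-fold higher number from compound 2 to compound 4 (0.14 log units; within the scatter).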

Compound 4, half-maximal inhibitory concentration: 520 nM
Estimate against measurement, compound 4: 1.9-fold (0.28 log units) above; measured number inside the range.
By their numbers in this assay, from the lowest: compounds 4 and 2 (each within the scatter of the next); then compounds 1 and 3 (each within the scatter of the next).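

In this assay, 4-methylpiperazin-1-yl in place of piperidin-1-yl on this aromatic carbon, opposite the ring oxygen, gives a 1.4-fold lower number from compound 2 to compound 4 (0.15 log units; within the scatter) and so stays within the scatter. Going by these compounds alone, this is the first measured step at this position, and it shows that a ring with 2 hetero atoms is tolerated here as well as one with 1 hetero atom. No evidence bears on why the two rings read alike. Going by these compounds, compound 1 carries a methyl group here but also differs from compound 2 on the aromatic ring, so what either ring adds over methyl stays unknown. On these data alone, whether morpholin-4-yl, dimethylamino or a carboxylic acid would fit here also remains open.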